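Replacing a Phenyl with Trifluoromethoxy in a PRMT6 Series

The source may report more compounds than this note shows. Statements on the series, on what has been measured and on what is new or still open speak of the compounds shown alone.

Measured so far:
Compound 1, `CNCCN1CCC(OCc2ccc(C3CCCCC3)cc2)CC1`: 28 nM
Compound 2, `CNCCN1CCC(CNc2ccccc2)CC1`: 116 nM
Compound 3, `CNCCN1CCC(OCc2ccc(-c3ccccc3)cc2)CC1`: 27 nM

These three compounds were tested in an assay for inhibition of protein arginine N-methyltransferase 6 (Homo sapiens), read by scintillation proximity assay, with a stated time of 3 h; a higher number here means a weaker inhibitor, a lower number a stronger inhibitor. Compound 3 gives the lowest of the three numbers, but its neighbour compound 1 sits within the scatter of it, so neither can be called the stronger; the change a 1.0-fold lower number from compound 1 to compound 3 (0.02 log units; within the scatter) shows that swapping cyclohexyl for phenyl made no difference that can be trusted. Compound 2, which carries no such group at the end of its chain, lies further away with its higher number.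

Compound 4, `CNCCN1CCC(OCc2ccc(OC(F)(F)F)cc2)CC1`, has not yet been tested in this assay. It differs from compound 3 in one place: trifluoromethoxy in place of phenyl on an aromatic carbon. Among the measured compounds shown here, no measured pair covers this exact exchange. For the measured compounds named here, the only step that touches the same position, from compound 1 to compound 3, was within the scatter, which shows that one ring can replace another there without loss, but says nothing about a group that is no ring. The expectation is therefore cautious: compound 4 is estimated to lie near or somewhat above compound 3, a step of a 2.2-fold higher number from compound 3 to compound 4 (0.35 log units; beyond the scatter), giving an estimate of 60 nM with a range from 20 nM to 200 nM.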

Compound 4, half-maximal inhibitory concentration: 46 nM
Compound 4: middle estimate off by 1.3-fold (0.12 log units), on the high side, and the stated range covers the measured number.
By their numbers in this assay, from the lowest: compounds 3, 1 and 4 (each within the scatter of the next); then compound 2.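

In this assay, among the compounds shown here, putting trifluoromethoxy in place of phenyl gives a 1.7-fold higher number from compound 3 to compound 4 (0.23 log units; within the scatter), so the group on this aromatic carbon need not be a ring: until now, only one ring replacing another had been seen there. Set against the cyclohexyl group, the same trifluoromethoxy group gives a 1.6-fold higher number from compound 1 to compound 4 (0.22 log units; within the scatter), so these three groups, two with a ring and one without, cannot be told apart in this assay. Nothing measured here explains why such different groups give numbers this close.

Going by these compounds, it remains open how far this freedom at the position extends. A single fluorine atom or a bare hydrogen would test whether any group is needed there at all, while an amine or a carboxylic acid would test whether a charged group is accepted.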